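Cyclohexanone dienone series: methoxy addition and cytotoxicity

The source may report more compounds than this note shows. Statements on the series, on what has been measured and on what is new or still open speak of the compounds shown alone.

Measured so far in an ADME assay on NHDF cells (Homo sapiens) for cytotoxicity, read by MTT assay, with a stated time of 72 h; a higher number here means a weaker inhibitor, a lower number a stronger inhibitor:
compound 1 `COc1cccc(/C=C2\CCC/C(=C\c3cccc(OC)c3OC)C2=O)c1` gives 16400 nM
compound 2 `COc1cc(/C=C2\CCC/C(=C\c3cccc(OC)c3OC)C2=O)cc(OC)c1` gives 13100 nM
compound 3 `COc1cccc(/C=C2\CCC/C(=C\c3ccc(OC)c(OC)c3)C2=O)c1` gives 11600 nM

The three values lie within the scatter of one another, so no order among them is claimed. One change is shared by two pairs. From compound 1 to compound 2 it is methoxy in place of hydrogen on an aromatic carbon and the step is a 1.3-fold lower number from compound 1 to compound 2 (0.10 log units; within the scatter). Compound 4 `COc1cc(/C=C2\CCC/C(=C\c3ccc(OC)c(OC)c3)C2=O)cc(OC)c1` is not yet measured; it differs from compound 3 by methoxy in place of hydrogen on an aromatic carbon, the same change at the same kind of place. The difference between the core of compound 1 and that of compound 3 is not broken down here. In this assay the step from compound 3 to compound 4 is expected to be a 1.2-fold lower number from compound 3 to compound 4 (0.10 log units; within the scatter), resting on the step from compound 1 to compound 2 a 1.3-fold lower number from compound 1 to compound 2 (0.10 log units; within the scatter) and on the value of compound 3 11600 nM. Compound 4 is therefore estimated at 9300 nM, between 5000 nM and 18000 nM.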

Compound 4, half-maximal inhibitory concentration: 6500 nM
Compound 4: the middle estimate sits 1.4-fold (0.16 log units) above what was measured, and the stated range covers the measured number.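

In this assay, methoxy in place of hydrogen on an aromatic carbon gives a 1.8-fold lower number from compound 3 to compound 4 (0.25 log units; within the scatter). The steps on the two cores cannot be told apart: the same change on two cores in this assay, a 1.3-fold lower number (0.10 log units; within the scatter) from compound 1 to compound 2 and a 1.8-fold lower number (0.25 log units; within the scatter) from compound 3 to compound 4, 1.4-fold (0.15 log units) apart, within the scatter of two such steps. The change therefore carries from the core of compound 1 to the core of compound 3 without a detectable difference, but each step lies within the scatter, so neither shows that the change itself moves the number on either core, and the two cores say nothing about others.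

The aromatic substituents shown are all methoxy groups. On these data alone, whether a hydroxy group, an amine or a carboxylic acid at the same kind of place would give a step beyond the scatter remains open.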